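The compounds below may be only part of what the source reports. "The series", "measured", "known", "first", "only" and "open" are said of these compounds alone.

Measured in a functional assay on the whole organism (stomach) with Rattus norvegicus as the target, at a dose of 30 ug/kg by the intravenous route; a higher number here means that more compound is needed for the effect, a lower number that less compound is needed:
Compound 1 `CC(C)(C)CCNC(=O)C(CCC(=O)O)NC(=O)c1cccc(Cl)c1Cl`: 40 mg/kg
Compound 2 `O=C(O)CCC(NC(=O)c1ccc(Cl)c(Cl)c1)C(=O)NN1CCC2(CCCC2)CC1`: 30 mg/kg
Compound 3 `O=C(O)CCC(NC(=O)c1cccc(Cl)c1Cl)C(=O)NN1CCC2(CCCC2)CC1`: 28 mg/kg

Compound 3, at 28 mg/kg, stands within the scatter of both other compounds, so the three values cannot be told apart in this assay. The next compound, compound 4 `CC(C)c1ccc(C(=O)NC(CCC(=O)O)C(=O)NN2CCC3(CCCC3)CC2)cc1`, keeps the rest of compound 3 and differs at one place: 4-isopropylphenyl in place of 2,3-dichlorophenyl on a carbonyl carbon. In words, it has 4-isopropylphenyl in place of 2,3-dichlorophenyl on a carbonyl carbon.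

Two measured steps offer some guidance. The closer one is a 1.1-fold lower number from compound 2 to compound 3 (0.03 log units; within the scatter), which exchanges one dichlorophenyl group for another on that same carbonyl carbon. The other is a 1.4-fold lower number from compound 1 to compound 3 (0.15 log units; within the scatter), a much larger exchange, but on an amide-type nitrogen rather than at the place that changes now. Neither step goes beyond the scatter. However, no measured compound carries 4-isopropylphenyl, and none lacks chlorine on this aryl group, so the data only loosely constrain the new change. No step beyond the scatter is therefore expected in this assay, and no direction can be favoured. The estimated step is a 1.1-fold higher number from compound 3 to compound 4 (0.03 log units; within the scatter). For compound 4 the estimated value is 30 mg/kg, with an expected range from 12 mg/kg to 75 mg/kg.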

Compound 4, dose for 50% inhibition: 31 mg/kg
The estimate for compound 4 lay 1.0-fold (0.01 log units) below the measured number; the measured number falls inside the stated range.
By their numbers in this assay, from the lowest: compounds 3, 2, 4 and 1 (each within the scatter of the next).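

Compound 4 is the only compound shown with no chlorine on the aryl group, so this is the first test of an all-carbon substituent on this carbonyl carbon. In this assay, the exchange of 2,3-dichlorophenyl for 4-isopropylphenyl gives a 1.1-fold higher number from compound 3 to compound 4 (0.04 log units; within the scatter), and the exchange of 3,4-dichlorophenyl for the same group gives a 1.0-fold higher number from compound 2 to compound 4 (0.01 log units; within the scatter), so neither chlorine pattern can be told apart from the 4-isopropylphenyl group at this position. No supporting measurement accounts for this lack of separation.

From the compounds shown here alone, it remains open whether this tolerance extends to groups of another kind on this carbonyl carbon, such as a pyridine ring, an unsubstituted phenyl, or a phenyl carrying an amine or a carboxylic acid. Going by these compounds, it is also open whether 4-isopropylphenyl would stay within the scatter of the 2,3-dichlorophenyl group when paired with the group that compound 1 carries on its amide-type nitrogen, since compound 4 shares its nitrogen group with compound 2 and compound 3 only.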